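This account rests on a few compounds, and the source may have more. Where it says the series, first, only, none or still open, it means among the compounds named here.

Measured so far:
compound 1 `CC(C)Cc1ccc(C(C)C(=O)NCc2ccc(F)cc2)cc1`: 27000 nM
compound 2 `CC(C)Cc1ccc(C(C)C(=O)NCc2ccc(C(C)(C)C)cc2)cc1`: 25000 nM

Both numbers come from an assay on brain for inhibition of Fatty-acid amide hydrolase 1 (Rattus norvegicus), read by scintillation counting, with a stated time of 10 min; a higher number here means a weaker inhibitor, a lower number a stronger inhibitor. Compound 1 stands highest of the two, but its nearest neighbour, compound 2, differs from it by a 1.1-fold lower number from compound 1 to compound 2 (0.03 log units; within the scatter), so the two sit together within the scatter and neither can be called the weaker.

Compound 3 `COc1ccccc1CNC(=O)C(C)c1ccc(CC(C)C)cc1` has not been measured. Compared with compound 1 the change is 2-methoxyphenyl in place of 4-fluorophenyl on a saturated chain carbon bound to an amide-type nitrogen. Among the compounds with values here, only one measured step touches the same region: the step from compound 1 to compound 2, which swapped one group for another on the ring at that position and gave a 1.1-fold lower number from compound 1 to compound 2 (0.03 log units; within the scatter), a change too small to count. On that evidence, changing the substituent and its position on this ring is expected to leave this assay essentially unchanged, with no step beyond the scatter.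

Compound 3 is therefore estimated at 25000 nM in this assay, within 10000 nM to 60000 nM, meaning an expected step of a 1.1-fold lower number from compound 1 to compound 3 (0.03 log units; within the scatter).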

Compound 3, half-maximal inhibitory concentration: 18000 nM
For compound 3 the middle estimate is 1.4-fold (0.14 log units) above the measured one; low and high end bracket the measured number.
By their numbers in this assay, from the lowest: compounds 3, 2 and 1 (each within the scatter of the next).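

Compound 3 brings a different kind of change from the one seen so far: 2-methoxyphenyl in place of 4-fluorophenyl alters both the group on the ring and its numbered place, and it brings in an oxygen and a hydrogen-bond acceptor. In this assay, within the data shown here, this gives a 1.5-fold lower number from compound 1 to compound 3 (0.18 log units; within the scatter), so even this broader change on the saturated chain carbon bound to the amide-type nitrogen produces no step that can be told from the scatter. Nothing measured here offers an explanation for this result.

As far as these compounds go, all three compounds share the rest of the core, so the effect of changes elsewhere remains unknown. From the compounds shown here alone, it also remains open whether an amine, a carboxylic acid or a longer chain in place of the 4-fluorophenyl would move the number beyond the scatter.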